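Benzothiazole thioether series: chain shape at the sulfur

The compounds below may be only part of what the source reports. "The series", "measured", "known", "first", "only" and "open" are said of these compounds alone.

Three members of this series have numbers in an assay on isolated protein for inhibition of protoporphyrinogen oxidase (Homo sapiens), read by capillary electrophoresis; a lower number here means a stronger inhibitor, a higher number a weaker inhibitor. Compound 1 `CCOC(=O)CSc1nc2cc(-n3nc(C(C)(C)C)sc3=O)c(F)cc2s1` gives 340 nM. Compound 2 `CCOC(=O)CSc1nc2cc(-n3nc(C(C)(C)C)sc3=O)c(Cl)cc2s1` gives 5820 nM; the step of a 17-fold higher number from compound 1 to compound 2 (1.23 log units; beyond the scatter) came with the change to chloro in place of fluoro on an aromatic carbon. Compound 3 `CCOC(=O)C(C)(C)Sc1nc2cc(-n3nc(C(C)(C)C)sc3=O)c(Cl)cc2s1` gives 34400 nM, the highest of the three numbers; it sits nearest to compound 2, separated by the step of a 5.9-fold higher number from compound 2 to compound 3 (0.77 log units; beyond the scatter) that accompanied 1-(ethoxycarbonyl)-1-methylethyl in place of (ethoxycarbonyl)methyl on the sulfur, and its number lies well above that of compound 1.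

Compound 4 `CCOC(=O)CCCSc1nc2cc(-n3nc(C(C)(C)C)sc3=O)c(Cl)cc2s1` has not yet been run in this assay. Its change from compound 3 is 3-(ethoxycarbonyl)propyl in place of 1-(ethoxycarbonyl)-1-methylethyl on a sulfur: the same atoms are present in both, but the ester-bearing chain now leaves the sulfur as an unbranched three-carbon link rather than a branched one-carbon link. The step that bears on this is a 5.9-fold higher number from compound 2 to compound 3 (0.77 log units; beyond the scatter), which showed that adding branching at the carbon on the sulfur raised the number by a modest amount. Going by the values given here, removing that branching is expected to bring the number back down, so a step of about a 3.4-fold lower number from compound 3 to compound 4 (0.54 log units; beyond the scatter) is expected in this assay, though the longer chain has no direct precedent here. Compound 4 is therefore estimated at 10000 nM, with a range from 3000 nM to 35000 nM.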

Compound 4, inhibition constant: 17700 nM
For compound 4 the middle estimate is 1.8-fold (0.25 log units) below the measured one; low and high end bracket the measured number.
By their numbers in this assay, from the lowest: compound 1; then compound 2; then compounds 4 and 3 (each within the scatter of the next).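

Notes on the chain at the sulfur: in this assay, the step from the branched chain to the unbranched one (a 1.9-fold lower number from compound 3 to compound 4 (0.29 log units; within the scatter)) does not separate 1-(ethoxycarbonyl)-1-methylethyl from 3-(ethoxycarbonyl)propyl on this sulfur. The lengthened unbranched chain still stands clear of the short one (a 3.0-fold higher number from compound 2 to compound 4 (0.48 log units; beyond the scatter)), so branching is not required for a higher number than that of the (ethoxycarbonyl)methyl chain. Among the three chloro compounds, both departures from (ethoxycarbonyl)methyl therefore go the same way, and compound 2 keeps the lowest number of that set, while neither compound 3 nor compound 4 goes against this. No measurement on hand accounts for this behaviour of the chains.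

The compounds shown leave open where a 2-(ethoxycarbonyl)ethyl chain on the sulfur would fall, and whether a carboxylic acid or an amide in place of the ethyl ester would change the number. They also leave open whether the 3-(ethoxycarbonyl)propyl and 1-(ethoxycarbonyl)-1-methylethyl chains would stay this close with fluoro in place of chloro on the aromatic carbon.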